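Swapping the amide group at the limit of the assay

A few compounds are considered here, and "the series" means these few. Any claim that something is new, unique, unknown or untested is made for them only; others in the source may bear on it.

Measured in a functional assay on A549 cells (Homo sapiens) for inhibition, read by MTT assay, with a stated time of 48 h; a lower number here means a stronger inhibitor, a higher number a weaker inhibitor:
Compound 1 `CC(C)n1c(/C=C2\SC(=O)N(CC(=O)N3CCCCC3)C2=O)nc2ccccc21`: 28200 nM
Compound 2 `CC1CN(C(=O)CN2C(=O)S/C(=C\c3nc4ccccc4n3C(C)C)C2=O)CC(C)O1`: > 50000 nM (a limit, not a number)

Compound 2 has no number in this assay, only a limit, and it stands at the limit of > 50000 nM in this assay, at which 1 of the 2 values shown sits. Compound 3 `CC(C)n1c(/C=C2\SC(=O)N(CC(=O)Nc3cc(C(C)(C)C)on3)C2=O)nc2ccccc21` keeps the shared core and changes the same place that separates compound 1 from compound 2, on a carbonyl carbon: (5-(tert-butyl)-1,2-oxazol-3-yl)amino in place of 2,6-dimethylmorpholin-4-yl on a carbonyl carbon. Here (5-(tert-butyl)-1,2-oxazol-3-yl)amino stands in place of 2,6-dimethylmorpholin-4-yl.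

Among the measured compounds shown here, only one measured step bears on this place: an at least 1.7-fold higher number from compound 1 to compound 2 (0.24 log units; that floor lies within the scatter). For the measured compounds named here, its floor lies within the scatter, so it sets no firm size for changes here, and no measured compound carries the entering group. Going by the values given here, compound 1, at 28200 nM, holds the only number at this place, so a value for compound 3 is expected in that neighbourhood. The expected step is an at least 2.0-fold lower number from compound 2 to compound 3 (0.30 log units; that floor lies within the scatter), towards a lower number, though only a modest one. For compound 3 the estimate is 25000 nM, with an expected range from 8000 nM to 50000 nM.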

Compound 3, half-maximal inhibitory concentration: > 50000 nM
Compound 3: only a limit was reported; the forecaster's own chance of this, stated with the estimate: 30%; middle value at least 2.0-fold (0.30 log units) from the limit.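

In this assay, the change to (5-(tert-butyl)-1,2-oxazol-3-yl)amino on this carbonyl carbon, which brings a five-membered aromatic ring and a hydrogen-bond donor, leaves compound 3 with > 50000 nM, a limit of the assay and not a number. Among the compounds shown here, the one step that can be read is an at least 1.7-fold higher number from compound 1 to compound 3 (0.24 log units; that floor lies within the scatter), so it sets no firm size for the change, and the step between the two limits cannot be read. Compound 1 therefore remains the only compound with a number at this place, and a second, quite different group has joined the limit: the limit of > 50000 nM in this assay, at which 2 of the 3 values shown sit.

The limits leave open what numbers compound 2 and compound 3 would carry, and so how these two groups rank against each other. Also open, on these data alone, is whether another group on this carbonyl carbon, such as pyrrolidin-1-yl or diethylamino, would give a number near that of compound 1 or a clearly lower one.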